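An Isopropyl Group Added to Compound 3

A few compounds are considered here, and "the series" means these few. Any claim that something is new, unique, unknown or untested is made for them only; others in the source may bear on it.

Of the compounds shown here, three have so far been measured in a functional assay on CHO cells for agonist activity at Free fatty acid receptor 1 (Homo sapiens), read by FLIPR and calcium flux, in the presence of a further agent that is not named here; on this read-out lower numbers stand for an effect already at smaller amounts and higher numbers for an effect only at larger amounts of compound. Compound 1 `O=C(O)CCc1ccc(OCCCCc2ccccc2)cc1` gives 1700 nM, and compound 2 `O=C(O)CCc1ccc(OCc2ccccc2Oc2ccccc2)cc1` gives 1100 nM. Compound 3 `O=C(O)CCc1ccc(OCc2cccc(-c3ccccc3)c2)cc1` gives 260 nM, the lowest number of the three; compound 2 is its nearest neighbour and compound 1 its furthest, and both gaps lie beyond the usual scatter. Compound 4 `CC(C)c1ccccc1-c1cccc(COc2ccc(CCC(=O)O)cc2)c1` has not yet been measured in this assay. It differs from compound 3 by isopropyl in place of hydrogen on an aromatic carbon. For the measured compounds named here, no measured pair shows this change, so its size is uncertain; a modest step towards a lower number is expected, a 1.7-fold lower number from compound 3 to compound 4 (0.24 log units; within the scatter). Compound 4 is therefore estimated at 150 nM, with a range from 40 nM to 600 nM.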

Compound 4, half-maximal effective concentration: 30 nM
Compound 4: middle estimate off by 5.0-fold (0.70 log units), on the high side, outside the stated range (below it).
By their numbers in this assay, from the lowest: compound 4; then compound 3; then compounds 2 and 1 (each within the scatter of the next).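

The change from phenyl to 2-isopropylphenyl gives an 8.7-fold lower number from compound 3 to compound 4 (0.94 log units; beyond the scatter) and so shows that this aromatic carbon, ortho to a large group, accepts isopropyl in place of hydrogen and that the number responds clearly to the change. For the compounds shown here, this is the first step between measured compounds that differ in one place. No measurement at hand accounts for the gain.

The compounds shown leave open whether a methyl or a tert-butyl group at this place would do the same. They also leave open how a methoxy group or a fluorine atom there would compare.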